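Swapping One Cyclopropyl Linker at a Shared Core

The compounds below may be only part of what the source reports. "The series", "measured", "known", "first", "only" and "open" are said of these compounds alone.

Measured in a functional assay on MCF7 cells (Homo sapiens) for inhibition, read by sulforhodamine B assay, with a stated time of 48 h; a lower number here means a stronger inhibitor of growth, a higher number a weaker inhibitor of growth:
compound 1 `COc1ccc2c(c1)NC(=O)CN2c1nc(COC(C)=O)nc2ccccc12`: 33 nM
compound 2 `COc1ccc2c(c1)NC(=O)CN2c1nc(OCC2CC2)nc2ccccc12`: 7.88 nM
compound 3 `COc1ccc2c(c1)NC(=O)CN2c1nc(NCCCO)nc2ccccc12`: 7.43 nM

Compound 2, at 7.88 nM, sits level with compound 3 within the scatter, and both lie clearly under compound 1. Compound 4 `COc1ccc2c(c1)NC(=O)CN2c1nc(NC2CC2)nc2ccccc12` has cyclopropylamino in place of cyclopropylmethoxy on an aromatic carbon. The closest measured change puts (3-hydroxypropyl)amino in place of cyclopropylmethoxy, and it gave only a 1.1-fold lower number from compound 2 to compound 3 (0.03 log units; within the scatter). The larger 4.2-fold lower number from compound 1 to compound 2 (0.62 log units; beyond the scatter) and a 4.4-fold lower number from compound 1 to compound 3 (0.65 log units; beyond the scatter) both start from acetoxymethyl, which is not involved here. No step beyond the scatter is therefore expected in this assay. The expected step is a 1.1-fold lower number from compound 2 to compound 4 (0.05 log units; within the scatter). For compound 4 the estimated value is 7 nM, with an expected range from 3 nM to 18 nM.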

Compound 4, concentration for 50% growth inhibition: 1.08 nM
The estimate for compound 4 lay 6.5-fold (0.81 log units) above the measured number; the whole stated range lies above it.
By their numbers in this assay, from the lowest: compound 4; then compounds 3 and 2 (each within the scatter of the next); then compound 1.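

In this assay, the ring carbon between two ring nitrogen atoms had looked indifferent to the swaps among the earlier groups, but it does respond: a 7.3-fold lower number from compound 2 to compound 4 (0.86 log units; beyond the scatter), and a 6.9-fold lower number from compound 3 to compound 4 (0.84 log units; beyond the scatter). Compound 3 already has a nitrogen on this carbon and compound 2 already has a cyclopropyl ring in its group, so only their combination in cyclopropylamino stands apart. The widest gap is to acetoxymethyl, with a 31-fold lower number from compound 1 to compound 4 (1.49 log units; beyond the scatter).

Nothing measured here gives the reason for this gain. Going by these compounds, whether methylamino or cyclobutylamino would match cyclopropylamino remains open.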